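This account rests on a few compounds, and the source may have more. Where it says the series, first, only, none or still open, it means among the compounds named here.

Of the compounds shown here, three built on one shared core have been tested in an ADME assay on microsomes from liver (Mus musculus, strain CD-1) for metabolic stability, read by LC-MS, tested at 2 uM (a lower number here means that the compound disappears faster, a higher number that the compound lasts longer), and a fourth awaits measurement.

Compound 1, `CN1CCC(NC(=O)c2ccncc2Nc2cc(-c3ccc4ccn(C)c4c3)c3nccnc3c2)CC1`, carries a 1-methylpiperidin-4-yl group on its amide-type nitrogen. In this assay compound 1 gives > 1 h, which is a limit of the assay rather than a number. Compound 2, `CC(=O)N1CCC(NC(=O)c2ccncc2Nc2cc(-c3ccc4ccn(C)c4c3)c3nccnc3c2)CC1`, differs only by acetyl in place of methyl on an amine nitrogen in a ring. In this assay compound 2 gives 0.117 h. That single change made an at least 8.5-fold lower number from compound 1 to compound 2 (0.93 log units; beyond the scatter).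

Compound 3, `CN1CC(NC(=O)c2ccncc2Nc2cc(-c3ccc4ccn(C)c4c3)c3nccnc3c2)C1`, differs from compound 1 by 1-methylazetidin-3-yl in place of 1-methylpiperidin-4-yl on an amide-type nitrogen. In this assay compound 3 gives > 1 h, again a limit and not a number. Because both values sit at the limit of > 1 h in this assay, at which 2 of the 3 values shown sit, the step that the two limits leave unreadable from compound 1 to compound 3 cannot be sized. Against compound 2, however, the step is clear: an at least 8.5-fold higher number from compound 2 to compound 3 (0.93 log units; beyond the scatter).

Compound 4, `CC(=O)N1CC(NC(=O)c2ccncc2Nc2cc(-c3ccc4ccn(C)c4c3)c3nccnc3c2)C1`, has not yet been tested. It differs from compound 3 by acetyl in place of methyl on an amine nitrogen in a ring. Within the data shown here, this is the same kind of change as the one from compound 1 to compound 2, though not the same: there the place was a six-membered non-aromatic ring with 1 nitrogen, three ring bonds from the ring atom that bears a large group, while here it is a four-membered non-aromatic ring with 1 nitrogen, two ring bonds from that atom. Since compound 3 already stands at a limit, the step from compound 3 to compound 4 is expected to be an at least 6.6-fold lower number from compound 3 to compound 4 (0.82 log units; beyond the scatter), resting on the step of an at least 8.5-fold lower number from compound 1 to compound 2 (0.93 log units; beyond the scatter). Compound 4 is therefore expected to give about 0.15 h, most likely between 0.05 h and 0.6 h.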

Compound 4, half-life in the Mus musculus assay: 0.817 h
Estimate against measurement, compound 4: 5.4-fold (0.74 log units) below; measured number above the stated range.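

In the Mus musculus assay compound 3 gives > 1 h which is a limit of the assay and not a number. In the Mus musculus assay compound 1 gives > 1 h which is likewise a limit of the assay and not a number. In the Mus musculus assay, measured against these limits, an at least 1.2-fold lower number from compound 3 to compound 4 (0.08 log units; that floor lies within the scatter) and an at least 1.2-fold lower number from compound 1 to compound 4 (0.08 log units; that floor lies within the scatter) give only floors, not true sizes. Set beside the earlier case, the change of methyl to acetyl on the ring nitrogen reads as follows: the same change on two cores in the Mus musculus assay, an at least 8.5-fold lower number (0.93 log units; beyond the scatter) from compound 1 to compound 2 and an at least 1.2-fold lower number (0.08 log units; that floor lies within the scatter) from compound 3 to compound 4; the limit leaves it open whether they differ. This shows that the change goes with a clearly lower number on the core of compound 1, and that, with acetyl present in both compounds, a 7.0-fold higher number from compound 2 to compound 4 (0.84 log units; beyond the scatter); it does not show that the change carries over to the core of compound 3 with the same size, or that it lowers the number there at all.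

The compounds shown leave open how far the number really falls on going from methyl to acetyl on the 1-methylazetidin-3-yl group, as long as the methyl compounds stand at the limit. They also leave open whether another group on that ring nitrogen, such as a free amine hydrogen, an ethyl group or a longer acyl chain like propanoyl, would behave as acetyl does on either core.

In a physicochemical assay for solubility, read by spectrophotometry, measured as kinetic solubility, at pH 8, tested at 500 uM (on this read-out lower numbers stand for lower solubility and higher numbers for higher solubility), compound 3 gives 170 ug/mL and compound 4 gives 244 ug/mL and these two values lie within the usual scatter of each other.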